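This account rests on a few compounds, and the source may have more. Where it says the series, first, only, none or still open, it means among the compounds named here.

Working notes on the series. Compound 1 `O=C(COCc1ccccc1)N1CCN(c2ccc(Cl)cc2)CC1` and compound 2 `O=C(COCc1ccccc1)N1CCN(c2ccc(F)cc2)CC1` share one core; compound 3 `O=C(COCc1ccncc1)N1CCC(c2ccc(F)cc2Cl)CC1` and compound 4 `O=C(COCc1ccncc1)N1CCC(c2ccc(Cl)cc2Cl)CC1` share another. In a functional assay on HEK293 cells for positive allosteric modulation of metabotropic glutamate receptor 5 (Homo sapiens), read by FLIPR and calcium flux (a higher number here means that more compound is needed for the effect, a lower number that less compound is needed), compound 2 gives 1100 nM. In this assay compound 1 gives 350 nM. The change between them, (chloro in place of fluoro on an aromatic carbon), made a step of a 3.1-fold lower number from compound 2 to compound 1 (0.50 log units; beyond the scatter). In this assay compound 3 gives 370 nM; this value and that of compound 1 lie within the scatter of each other, while compound 2 sits at a higher number than compound 3. The difference between the two cores is not broken down here.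

Compound 4 is not yet measured. It differs from compound 3 by chloro in place of fluoro on an aromatic carbon. This is the same kind of change as that from compound 2 to compound 1, but the place is not the same: in compound 3 the aromatic carbon is meta to a chloro group and para to a large group, whereas in compound 2 it is only para to a large group. Among the compounds with values here, the step from compound 2 to compound 1 is the only measured guide for this kind of change. The step expected in this assay is a 2.6-fold lower number from compound 3 to compound 4 (0.42 log units; beyond the scatter), and it rests on a 3.1-fold lower number from compound 2 to compound 1 (0.50 log units; beyond the scatter), with the changed surroundings of the place leaving room for a smaller or larger step. Compound 4 is expected to give 140 nM in this assay, within a range from 50 nM to 400 nM.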

Compound 4, half-maximal effective concentration: 390 nM
Beside the measured number, compound 4's estimate is 2.8-fold (0.44 log units) below it; the measured number falls inside the stated range.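

In this assay the new step is a 1.1-fold higher number from compound 3 to compound 4 (0.02 log units; within the scatter), so chloro in place of fluoro on an aromatic carbon does not repeat on the core of compound 3 what it did on the core of compound 1, and the two steps differ: the same change on two cores in this assay, a 3.1-fold lower number (0.50 log units; beyond the scatter) from compound 2 to compound 1 and a 1.1-fold higher number (0.02 log units; within the scatter) from compound 3 to compound 4, 3.3-fold (0.52 log units) apart, beyond the scatter of two such steps.

A step measured on one of these cores is therefore no reliable guide to the size of the same change on the other core in this series. Within the data shown here, what this does not show is which structural difference separates the two results, as the pairs differ both in their cores and in the chloro group that lies meta to the changed carbon in compound 3, and each core offers only one pair, so no general rule for either core can be drawn.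

The compounds shown leave open how bromo, methyl or trifluoromethyl at the same place would behave on each core, and whether the step on the core of compound 3 would change without that chloro group. Also open, going by these compounds, is whether the two cores would respond alike to a change at another place, such as an added amine or a longer chain.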